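The compounds below may be only part of what the source reports. "The series", "measured", "known", "first", "only" and "open" are said of these compounds alone.

Three compounds share one core and were tested in an assay on CHO cells for displacement of a labelled ligand from adenosine receptor A3 (Homo sapiens), read by scintillation counting, tested at 10 uM; on this read-out higher numbers stand for more inhibition at the one concentration tested (going by the name of the read-out) and lower numbers for less inhibition. Compound 1 `CC(C)(C)Cc1csc(N)c1C(=O)c1ccc(Cl)cc1` carries a hydrogen at the ring position of interest and gives 5%. Compound 2 `CC(C)(C)Cc1c(-c2ccoc2)sc(N)c1C(=O)c1ccc(Cl)cc1` carries a furan-3-yl at that position and gives 1%. Compound 3 `CC(C)(C)Cc1c(-c2cccnc2)sc(N)c1C(=O)c1ccc(Cl)cc1` carries a pyridin-3-yl there and gives 1%. On these numbers compound 3 stands level with compound 2 at the digits shown, the two together being the lowest of the three, and the step of a number 4 percentage points lower from compound 1 to compound 3 (within the scatter) lies within the scatter, so none of the three is set apart from the others.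

Compound 4 `CC(C)(C)Cc1c(-c2ccccn2)sc(N)c1C(=O)c1ccc(Cl)cc1` differs from compound 3 in one place: pyridin-2-yl in place of pyridin-3-yl on an aromatic carbon. The measured steps that bear on this change are the earlier swaps at the same position: a number 4 percentage points lower from compound 1 to compound 2 (within the scatter), a number 4 percentage points lower from compound 1 to compound 3 (within the scatter) and, closest in kind, no change at the digits printed from compound 2 to compound 3 (within the scatter), where one aromatic ring replaced another without any movement beyond the scatter. Among the measured compounds shown here, no compound shows inhibition that the scatter would set apart from none at all. Compound 4 is therefore expected to show a number 1 percentage points higher from compound 3 to compound 4 (within the scatter). The value estimated for compound 4 is 2%, with a range from -4% to 10%.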

Compound 4, a percentage reported as inhibition, at one concentration (the size of the read-out at that concentration, not a potency): 1%
For compound 4 the middle estimate is 1 percentage points above the measured one, and the stated range covers the measured number.
By their numbers in this assay, from the lowest: compounds 2, 3, 4 and 1 (each within the scatter of the next).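

In this assay, compound 3 and compound 4 have the same atoms joined differently, and exchanging pyridin-3-yl for pyridin-2-yl gives no change at the digits printed from compound 3 to compound 4 (within the scatter), so the earlier finding of no readable movement now extends to a change in how the same ring is attached, not only to a change of ring. Comparisons with the other groups on this carbon, next to the ring sulfur, read the same way, with no change at the digits printed from compound 2 to compound 4 (within the scatter) and a number 4 percentage points lower from compound 1 to compound 4 (within the scatter), so a third aromatic ring here also stands within the scatter of the plain hydrogen. Nothing in the available data offers an explanation for this flat result.

The compounds shown leave open whether a group of another kind on this carbon, such as an amine, a carboxylic acid or a longer alkyl chain, would give a number that stands clear of the scatter. Also open, going by these compounds, is whether replacing the neopentyl group, which all four compounds keep, with a shorter ethyl chain would change the picture at this position.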